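The source may report more compounds than this note shows. Statements on the series, on what has been measured and on what is new or still open speak of the compounds shown alone.

Working notes on the series. Compound 1 `O=C(CCC(=O)OCCCCCCSc1ccc([N+](=O)[O-])c2nonc12)Nc1cccc(Cl)c1` and compound 2 `O=C(CCC(=O)OCCCCCCSc1ccc([N+](=O)[O-])c2nonc12)Nc1ccc(C(F)(F)F)cc1` share one core and differ only in the aryl group on the amide-type nitrogen. In an assay on isolated protein for inhibition of glutathione S-transferase Mu 2 (Homo sapiens), with a stated time of 10 min (on this read-out higher numbers stand for weaker inhibition and lower numbers for stronger inhibition), compound 1 gives 1100 nM, and compound 2 gives 90 nM. Going by the values given here, the step of a 12-fold lower number from compound 1 to compound 2 (1.09 log units; beyond the scatter) is the only measured step so far, and it leaves compound 2 with the lowest number of the two.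

Compound 3 `O=C(CCC(=O)N1CCOCC1)OCCCCCCSc1ccc([N+](=O)[O-])c2nonc12` is the next candidate. Its change from compound 2 is morpholin-4-yl in place of (4-(trifluoromethyl)phenyl)amino on a carbonyl carbon. Among the compounds with values here, the one measured step bears on it only in part: it showed that altering the group on the amide-type nitrogen moves the number by a large amount, as seen in a 12-fold lower number from compound 1 to compound 2 (1.09 log units; beyond the scatter), but it exchanged one aryl group for another, whereas compound 3 removes the aryl group and the donor entirely and brings in a ring with two hetero atoms. Within the data shown here, no measured pair covers such a change, so the direction is uncertain; the expected step for compound 3 is a 6.7-fold higher number from compound 2 to compound 3 (0.82 log units; beyond the scatter), a weakening beyond the scatter. Compound 3 is therefore estimated at 600 nM, with a range from 150 nM to 3000 nM.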

Compound 3, half-maximal inhibitory concentration: 170 nM
Compound 3: the middle estimate sits 3.5-fold (0.55 log units) above what was measured; the measured number falls inside the stated range.
By their numbers in this assay, from the lowest: compounds 2 and 3 (each within the scatter of the next); then compound 1.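

In this assay, replacing (4-(trifluoromethyl)phenyl)amino on this carbonyl carbon with morpholin-4-yl gives a 1.9-fold higher number from compound 2 to compound 3 (0.28 log units; within the scatter), even though the aromatic ring and the amide hydrogen are gone, so within the compounds shown neither is needed for a number at this level. The same morpholin-4-yl in place of (3-chlorophenyl)amino gives a 6.5-fold lower number from compound 1 to compound 3 (0.81 log units; beyond the scatter), which makes compound 1 the one that stands apart and shows that an aryl group at this position does not by itself bring the lowest numbers, since compound 1 carries one and compound 3 carries none. Nothing available explains why these two aryl groups part so widely or why the non-aromatic ring keeps pace with one of them.

From the compounds shown here alone, it remains open whether the ring oxygen of morpholin-4-yl matters, which piperidin-1-yl on the same carbonyl carbon would test, and whether an open-chain amine such as dimethylamino serves as well as a ring. (4-Chlorophenyl)amino would also separate the effect of the chlorine from that of its place on the ring, a question that compound 1 and compound 2 cannot settle between them.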